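Chloro in Place of Fluoro on the Core of Compound 1

The source may report more compounds than this note shows. Statements on the series, on what has been measured and on what is new or still open speak of the compounds shown alone.

Three compounds sharing one core were examined in an ADME assay on microsomes from liver (Mus musculus) for metabolic stability, with a stated time of 30 min; on this read-out higher numbers stand for a more stable compound and lower numbers for a less stable compound. Compound 1, `CCn1c(=O)/c(=C2\Sc3ccc(F)cc3N2C)s/c1=C\c1ccccn1`, gives 19%. Compound 2, `CCn1c(=O)/c(=C2\Sc3c(F)cccc3N2C)s/c1=C\c1ccccn1`, gives 12%, a difference from compound 1 that lies within the scatter, so the two cannot be ordered. Compound 3, `CCn1c(=O)/c(=C2\Sc3cccc(Cl)c3N2C)s/c1=C\c1ccccn1`, gives 38%, a gap from compound 1 that lies beyond the scatter. On these three numbers compound 1 thus stands second highest, close to compound 2 and clearly apart from compound 3.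

The unmeasured compound 4, `CCn1c(=O)/c(=C2\Sc3ccc(Cl)cc3N2C)s/c1=C\c1ccccn1`, differs from compound 1 in a single place: chloro in place of fluoro on an aromatic carbon. For the measured compounds named here, no pair of measured compounds shows exactly this exchange, so the size of the step cannot be read from data; it can only be expected. Going by the values given here, compound 3, the one compound carrying chloro, gives 38%, which is the highest of the three values and argues for a rise rather than a fall, though its chloro sits elsewhere on the ring. The expected step is therefore a moderate one upward, a number 7 percentage points higher from compound 1 to compound 4 (within the scatter). Compound 4 is estimated at 26% in this assay, with a range from 12% to 44%.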

Compound 4, percent of the compound remaining: 37%
For compound 4 the middle estimate is 11 percentage points below the measured one, and the stated range covers the measured number.
By their numbers in this assay, from the lowest: compounds 2 and 1 (each within the scatter of the next); then compounds 4 and 3 (each within the scatter of the next).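

At this aromatic carbon, meta to a fused ring and para to a fused ring, chloro in place of fluoro gives a number 18 percentage points higher from compound 1 to compound 4 (beyond the scatter) in this assay. For the compounds shown here, none of the earlier compounds formed a pair with this exchange, and the only one carrying chloro had it elsewhere on the ring, so this pair is the first to show that this single exchange, at this position and on the shared core, moves the read-out beyond the scatter toward a more stable compound. Nothing available on any measured property bears on the reason for this rise.

The compounds shown leave open how the parent compound with hydrogen on this carbon would compare, and whether a larger halogen such as bromo, or a methyl, a methoxy, a nitrile or an amine, would extend the rise or reverse it. They also leave open whether the same exchange would give a step of similar size at the other ring position that carries fluoro in the series, since this single pair is all that speaks to the change.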